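The source may report more compounds than this note shows. Statements on the series, on what has been measured and on what is new or still open speak of the compounds shown alone.

Of the compounds shown here, three built on one shared core have been tested in a functional assay on HCT-116 cells (Homo sapiens) for antiproliferative activity, read by MTT assay, with a stated time of 72 h; a higher number here means a weaker inhibitor, a lower number a stronger inhibitor. Compound 1 `O=C1COc2ccc(-c3cccc(NS(=O)(=O)c4ccc(F)cc4)c3)cc2N1c1ccccc1` reaches only the limit of this assay, giving > 40000 nM, which is a limit rather than a number. Compound 2 `O=C1COc2ccc(-c3cnc(Cl)c(NS(=O)(=O)c4ccc(F)cc4)c3)cc2N1c1ccc(F)cc1` gives 34200 nM in this assay. Compound 3 `COc1ncc(-c2ccc3c(c2)N(c2ccc(F)cc2)C(=O)CO3)cc1NS(=O)(=O)c1ccc(F)cc1` likewise stops at the limit of this assay, with > 40000 nM, again a limit and not a number. Among the measured compounds shown here, the only step between measured compounds that differ in a single place, an at least 1.1-fold higher number from compound 2 to compound 3 (0.06 log units; that floor lies within the scatter), brings the methoxy compound to that limit, so compound 3 stands at the limit of > 40000 nM in this assay, at which 2 of the 3 values shown sit, with no measured number of its own.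

Compound 4 `COc1ncc(-c2ccc3c(c2)NC(=O)CO3)cc1NS(=O)(=O)c1ccc(F)cc1` differs from compound 3 by a single change, (hydrogen in place of 4-fluorophenyl on an amide-type nitrogen in a ring). For the measured compounds named here, none of the measured steps touches the amide-type nitrogen; the one measured step concerns a substituent on an aromatic carbon, so there is no measured step that bears on this change. On that basis the step of a number no higher from compound 3 to compound 4 (the limit leaves the size open) is expected to be none beyond the scatter, with compound 4 most likely remaining at the limit. Compound 4 is therefore estimated to give about 40000 nM in this assay, within a range from 20000 nM to 80000 nM.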

Compound 4, half-maximal inhibitory concentration: 24900 nM
The estimate for compound 4 lay 1.6-fold (0.21 log units) above the measured number; measured number inside the range.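

The amide-type nitrogen in the ring had not been varied in any earlier step, and in this assay replacing 4-fluorophenyl with hydrogen there gives an at least 1.6-fold lower number from compound 3 to compound 4 (0.20 log units; that floor lies within the scatter). Compound 4 gives 24900 nM, so with hydrogen on this nitrogen the series still yields a measured number, and the 4-fluorophenyl group is not required for one. The smallest size this step can have does not take the change beyond the scatter. Compound 3 stands at a limit and not at a number, so the full size of the step stays unknown: the limit of > 40000 nM in this assay, at which 2 of the 4 values shown sit.

Going by these compounds, whether a methyl group, a longer chain or a chain ending in an amine on this nitrogen would move the number further, in either direction, remains open. On these data alone, it is also open whether the exchange of 4-fluorophenyl for hydrogen would give a similar step on the compound carrying chloro in place of methoxy on the aromatic carbon.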